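The source may report more compounds than this note shows. Statements on the series, on what has been measured and on what is new or still open speak of the compounds shown alone.

Compound 3 `Cc1cccc(F)c1-c1nc(CN2CCC(C(=O)NCCCN3C[C@H](C)C[C@H](C)C3)CC2)c(C)o1` is one of three compounds whose tolerance has been read in an ADME assay on Huh7.5.1 cells (Homo sapiens) for cytotoxicity, read by ATP content, with a stated time of 48 h; a higher number here means that more compound is tolerated, a lower number that less compound is tolerated. In this assay compound 3 gives 13000 nM. Compound 1 `Cc1cccc(Cl)c1-c1nc(CN2CCC(C(=O)NCCCN3CCCC(C)C3)CC2)c(C)o1` gives 16400 nM in this assay, and compound 2 `Cc1cccc(Cl)c1-c1nc(CN2CCC(C(=O)NCCCN3CCC(C)(C)CC3)CC2)c(C)o1` gives 11700 nM; compound 3 lies within the scatter of both, so no order among the three can be drawn from these numbers.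

Compound 4 `Cc1ccc(-c2nc(CN3CCC(C(=O)NCCCN4C[C@H](C)C[C@H](C)C4)CC3)c(C)o2)c(C)c1` differs from compound 3 by the change (2,4-dimethylphenyl in place of 2-fluoro-6-methylphenyl on an aromatic carbon). Among the measured compounds shown here, the one measured step, a 1.4-fold lower number from compound 1 to compound 2 (0.15 log units; within the scatter), concerns the saturated amine end of the chain and not the aryl group on the core, so no measured step bears on the change from compound 3 to compound 4. The three measured compounds all share an aryl group with one substituent on each side of the point of attachment, and nothing among them tests a 2,4-dimethylphenyl.

For the measured compounds named here, with no step to draw on, the expectation for compound 4 is a number close to that of compound 3, the expected step being no change at the digits printed from compound 3 to compound 4 (within the scatter). Compound 4 is therefore estimated at 13000 nM in this assay, with an expected range from 5000 nM to 35000 nM.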

Compound 4, half-maximal cytotoxic concentration: 4110 nM
Compound 4: the middle estimate sits 3.2-fold (0.50 log units) above what was measured; measured number outside the range, below it.
By their numbers in this assay, from the lowest: compound 4; then compounds 2, 3 and 1 (each within the scatter of the next).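

In this assay, the aryl group on the shared core proves able to move the number: with the amine end of the chain held constant, 2,4-dimethylphenyl in place of 2-fluoro-6-methylphenyl gives a 3.2-fold lower number from compound 3 to compound 4 (0.50 log units; beyond the scatter). The earlier step, a 1.4-fold lower number from compound 1 to compound 2 (0.15 log units; within the scatter), lay at the amine end of the chain and stayed within the scatter, so this is the first step shown to exceed it. The two aryl groups match in heavy atoms, hydrogen-bond donors and hydrogen-bond acceptors, and no measurement shown accounts for the lower number.

Whether the step follows from the loss of fluorine or from the different placement of the methyl groups cannot be told from these compounds. As far as these compounds go, how a 2,6-dimethylphenyl or an unsubstituted phenyl would read at this position in this assay also remains open.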